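From Methyl to Propoxy on a Spleen-Cell Activator

A few compounds are considered here, and "the series" means these few. Any claim that something is new, unique, unknown or untested is made for them only; others in the source may bear on it.

This piece follows a small set of compounds tested in a functional assay (spleen, spleen) for activation, with Mus musculus as the target; on this read-out lower numbers stand for an effect already at smaller amounts and higher numbers for an effect only at larger amounts of compound. Compound 1, with structure `Cc1nc(N)c2nc(O)n(Cc3ccccc3)c2n1`, gives 1 uM in this assay. Compound 2, with structure `Cc1ccc(Cn2c(O)nc3c(N)ncnc32)cc1`, gives 10 uM. Compound 3, with structure `COc1nc2c(N)ncnc2n1Cc1ccccc1`, reaches only the limit of the assay at > 10 uM, so no number is known for it. Among the two compounds with a number, compound 1 stands lowest, and its gap to compound 2 lies beyond the usual scatter of repeated measurements. Compound 4, with structure `CCCOc1nc(N)c2nc(O)n(Cc3ccccc3)c2n1`, has not yet been measured. It differs from compound 1 in a single place: propoxy in place of methyl on an aromatic carbon. No pair of measured compounds differs in only one place, so the weight of this change cannot be read from the data shown. The exchange of a methyl for a propoxy on an aromatic carbon is expected to give a step of a 2.0-fold higher number from compound 1 to compound 4 (0.30 log units; within the scatter), leaning toward a higher number. Compound 4 is estimated at 2 uM, with a range from 0.5 uM to 10 uM.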

Compound 4, minimum effective concentration: 0.01 uM
The estimate for compound 4 lay 200-fold (2.30 log units) above the measured number, outside the stated range (below it).
By their numbers in this assay, from the lowest: compound 4; then compound 1; then compound 2.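

Putting propoxy on the aromatic carbon between two ring nitrogen atoms gives a 100-fold lower number from compound 1 to compound 4 (2.00 log units; beyond the scatter) in this assay. Among the compounds shown here, this is the first pair in the set that differs in one place only, so it is the first direct sign that this position can strongly change the read-out. It also shows that the larger group, with its added oxygen and hydrogen-bond acceptor, is tolerated here and goes with activity at much smaller amounts of compound.

This single step cannot separate the part played by the oxygen from that of the chain, and a plain propyl chain, a longer alkoxy chain or an amine at the same place would be needed to tell them apart. Compound 3 offers only a limit of the assay and no number: the limit of > 10 uM in this assay, at which 1 of the 4 values shown sits.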